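This account rests on a few compounds, and the source may have more. Where it says the series, first, only, none or still open, it means among the compounds named here.

Compound 1 `C[Se]/C(=N\C(=O)c1ccco1)NC(=O)c1ccco1` is the starting point of this comparison. In a functional assay on PC-3 cells (Homo sapiens) for cytotoxicity, read by MTT assay, with a stated time of 72 h (on this read-out higher numbers stand for lower toxicity in this test and lower numbers for higher toxicity in this test), compound 1 gives only a limit of the assay, > 100000 nM, so no number is known for it. Compound 2 `C[Se]/C(=N\C(=O)c1sccc1Cl)NC(=O)c1sccc1Cl` in this assay likewise reaches only a limit, > 100000 nM. Compound 1 thus stands at the limit of > 100000 nM in this assay, at which 2 of the 2 values shown sit. Compound 3 `O=C(/N=C(/NC(=O)c1ccco1)[Se]Cc1ccccc1)c1ccco1` differs from compound 1 in one place: phenyl in place of hydrogen on a saturated chain carbon bound to a selenium atom. Within the data shown here, with both known values sitting at the limit, no measured step sets a direction, so the step is expected to be an at least 1.2-fold lower number from compound 1 to compound 3 (0.09 log units; that floor lies within the scatter), none beyond the scatter. Compound 3 is therefore estimated at 80000 nM, within a range from 20000 nM to 200000 nM.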

Compound 3, concentration lethal to 50% of the cells: 84800 nM
Compound 3: the middle estimate sits 1.1-fold (0.03 log units) below what was measured; the measured number falls inside the stated range.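

In this assay, among these compounds, compound 3 gives 84800 nM, the only value shown that is a number and not a limit. Phenyl in place of hydrogen on a saturated chain carbon bound to a selenium atom therefore gives a step that can be read in one direction: an at least 1.1-fold lower number from compound 1 to compound 3 (0.07 log units; that floor lies within the scatter). Its true size stays unknown, and the other values shown offer no number to compare with: the limit of > 100000 nM in this assay, at which 2 of the 3 values shown sit.

On these data alone, whether benzyl gives a similar step on the core of compound 2 remains open. So does what an ethyl group or a carboxylic acid would give in place of the phenyl.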